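The source may report more compounds than this note shows. Statements on the series, on what has been measured and on what is new or still open speak of the compounds shown alone.

Compound 1 `CCCCCCCCCCCCCCCCCC(=O)N1CCOCC1` gives 53.1 ug/mL in a functional assay on NCI-H460 cells (Homo sapiens) for antiproliferative activity, read by sulforhodamine B assay, with a stated time of 48 h; a lower number here means a stronger inhibitor of growth, a higher number a weaker inhibitor of growth.
Compound 2 `CCCCCCCCCCCCCCCC(=O)N1CCCC1` gives 5.9 ug/mL.
Compound 3 `CCCCCCCCCCCCCCCC(=O)N1CCOCC1` gives 34.1 ug/mL.

Among these three, compound 2 has the lowest number: a 5.8-fold higher number from compound 2 to compound 3 (0.76 log units; beyond the scatter), and its gap to compound 1 is larger still, so compound 2 stands beyond the scatter from both of the others. Compound 4 `CCCCCCCCCCCCCCCCCC(=O)N1CCCC1` has not yet been measured in this assay. (ethyl in place of hydrogen on a saturated chain carbon, ten or more bonds along the chain from a carbonyl carbon). Among the measured compounds shown here, the one measured step that bears on this change runs the other way along the chain: a 1.6-fold lower number from compound 1 to compound 3 (0.19 log units; within the scatter), and it stayed within the scatter. The change from compound 2 to compound 4 keeps the pyrrolidin-1-yl on the carbonyl carbon and alters only the chain, as in that pair, so any step in this assay is expected to be small, at most a slightly higher number, and not clearly beyond the scatter. The larger step in the set, a 5.8-fold higher number from compound 2 to compound 3 (0.76 log units; beyond the scatter), concerns the group on the carbonyl carbon and says nothing about the chain. The estimate for compound 4 is therefore 8 ug/mL, with a range from 4 ug/mL to 16 ug/mL. The expected step is a 1.4-fold higher number from compound 2 to compound 4 (0.13 log units; within the scatter).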

Compound 4, concentration for 50% growth inhibition: 10.8 ug/mL
Beside the measured number, compound 4's estimate is 1.4-fold (0.13 log units) below it; low and high end bracket the measured number.
By their numbers in this assay, from the lowest: compounds 2 and 4 (each within the scatter of the next); then compounds 3 and 1 (each within the scatter of the next).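

On the pyrrolidin-1-yl amide, ethyl in place of hydrogen on a saturated chain carbon, ten or more bonds along the chain from a carbonyl carbon, gives a 1.8-fold higher number from compound 2 to compound 4 (0.26 log units; within the scatter) in this assay, so this chain change now stays within the scatter on a second core and not only on the morpholin-4-yl amides: the same change on two cores in this assay, a 1.6-fold lower number (0.19 log units; within the scatter) from compound 1 to compound 3 and a 1.8-fold lower number (0.26 log units; within the scatter) from compound 4 to compound 2, 1.2-fold (0.07 log units) apart, within the scatter of two such steps

Pyrrolidin-1-yl in place of morpholin-4-yl on a carbonyl carbon gives a 4.9-fold lower number from compound 1 to compound 4 (0.69 log units; beyond the scatter), which shows that the step beyond the scatter seen earlier with this exchange also appears on the other chain: the same change on two cores in this assay, a 5.8-fold higher number (0.76 log units; beyond the scatter) from compound 2 to compound 3 and a 4.9-fold higher number (0.69 log units; beyond the scatter) from compound 4 to compound 1, 1.2-fold (0.07 log units) apart, within the scatter of two such steps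

Across these four compounds, the steps beyond the scatter all come with the change of group on the carbonyl carbon and none with the change of chain, and no compound here goes against that pattern.

The compounds shown leave open whether the group on the carbonyl carbon would give a similar step if it were piperidin-1-yl or a simple diethylamino group. They also leave open whether the chain would remain so unresponsive if it were much shorter or much longer, or if it ended in a carboxylic acid or an amine.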